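A few compounds are considered here, and "the series" means these few. Any claim that something is new, unique, unknown or untested is made for them only; others in the source may bear on it.

Measured compounds in a functional assay on Jurkat cells for inhibition of nuclear factor NF-kappa-B complex (Homo sapiens); on this read-out higher numbers stand for weaker inhibition and lower numbers for stronger inhibition:
compound 1, `CCOC(=O)c1cnc(CC)nc1NN1C(=O)C=C(C)C1=O`, gives 10000 nM.
compound 2, `CCOC(=O)c1cnc(-c2cccc(OC)c2)nc1NN1C(=O)C=C(C)C1=O`, gives 5000 nM.

Among the compounds with values here, only two compounds have numbers in this assay so far. Within the data shown here, compound 2 and compound 1 lie within the usual scatter of each other; the one step between them, a 2.0-fold lower number from compound 1 to compound 2 (0.30 log units; within the scatter), does not separate them. Compound 2 therefore has no established position against compound 1 other than that the two are indistinguishable on these data.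

Compound 3, `CCOC(=O)c1cnc(-c2ccc(C(F)(F)F)cc2)nc1NN1C(=O)C=C(C)C1=O`, differs from compound 2 by a single change: 4-(trifluoromethyl)phenyl in place of 3-methoxyphenyl on an aromatic carbon. Among the measured compounds shown here, no measured step compares one aryl group with another at this position; the only step available, from ethyl to 3-methoxyphenyl, is the one just given and stays within the scatter. There is thus no measured basis for expecting a step beyond the scatter from compound 2 to compound 3, in either direction, and the uncertainty in the expectation is correspondingly wide.

The estimate for compound 3 is 5000 nM, with an expected range from 1500 nM to 15000 nM, which corresponds to an expected step of no change at the digits printed from compound 2 to compound 3 (within the scatter) in this assay.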

Compound 3, half-maximal inhibitory concentration: 400 nM
For compound 3 the middle estimate is 13-fold (1.10 log units) above the measured one; the whole stated range lies above it.
By their numbers in this assay, from the lowest: compound 3; then compounds 2 and 1 (each within the scatter of the next).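

In this assay the carbon para to the ethoxycarbonyl group now proves responsive to its substituent: 4-(trifluoromethyl)phenyl gives a 13-fold lower number from compound 2 to compound 3 (1.10 log units; beyond the scatter) when it replaces 3-methoxyphenyl and a 25-fold lower number from compound 1 to compound 3 (1.40 log units; beyond the scatter) when it replaces ethyl. The earlier change from ethyl to 3-methoxyphenyl did not separate compound 1 from compound 2, so an aryl group here does not by itself give the lower number, and the substituted phenyl in compound 3 matters; compound 3 now stands lowest of the three, with both of its steps beyond the scatter. No supporting measurement on this series speaks to the reason for the step.

The change from compound 2 to compound 3 alters both the substituent and its ring position, so 4-methoxyphenyl or 3-(trifluoromethyl)phenyl at this carbon would be needed to tell those two contributions apart. From the compounds shown here alone, it also remains open whether the step carries over to other groups on the phenyl ring, such as a chlorine atom or a nitrile, and whether it holds when the ethyl ester of the shared core gives way to a carboxylic acid or an amide.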